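A few compounds are considered here, and "the series" means these few. Any claim that something is new, unique, unknown or untested is made for them only; others in the source may bear on it.

Measured compounds:
compound 1 `Nc1nn(Cc2cn(CCC(F)(F)C(F)(F)C(F)(F)C(F)(F)C(F)(F)C(F)(F)F)nn2)c2nc(-c3ccccc3)cc(C(F)(F)F)c12`, 98.2 ug/mL
compound 2 `CCCCCCCCCCn1cc(Cn2nc(N)c3c(C(F)(F)F)cc(-c4ccccc4)nc32)nn1`, 27.1 ug/mL
compound 3 `Nc1nn(Cc2cn(-c3ccc([N+](=O)[O-])cc3)nn2)c2nc(-c3ccccc3)cc(C(F)(F)F)c12`, 98.8 ug/mL

In a functional assay on U-937 cells (Homo sapiens) for cytotoxicity, read by MTT assay, with a stated time of 24 h (on this read-out lower numbers stand for stronger inhibition and higher numbers for weaker inhibition), compound 3 gives the highest of the three numbers; compound 1 lies within the scatter of it, while compound 2 sits well below. Among the measured compounds shown here, the one measured step, a 3.6-fold higher number from compound 2 to compound 3 (0.56 log units; beyond the scatter), swaps a long chain for an aryl group. Compound 4 `Nc1nn(Cc2cn(CC(=O)Nc3cccc(F)c3)nn2)c2nc(-c3ccccc3)cc(C(F)(F)F)c12` differs from compound 3 by ((3-fluorophenyl)carbamoyl)methyl in place of 4-nitrophenyl on an aromatic nitrogen. This change keeps an aryl-bearing group on the same nitrogen rather than returning to a chain, so the measured step offers only loose guidance; no step beyond the scatter is expected, a 1.0-fold lower number from compound 3 to compound 4 (0.02 log units; within the scatter). Compound 4 is therefore estimated at 95 ug/mL, within a range of 40 ug/mL to 200 ug/mL.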

Compound 4, half-maximal inhibitory concentration: 43.5 ug/mL
For compound 4 the middle estimate is 2.2-fold (0.34 log units) above the measured one; the range from low to high includes it.
By their numbers in this assay, from the lowest: compounds 2 and 4 (each within the scatter of the next); then compounds 1 and 3 (each within the scatter of the next).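

On this aromatic nitrogen, a group carrying an aryl ring need not give a high number in this assay: ((3-fluorophenyl)carbamoyl)methyl in place of 4-nitrophenyl gives a 2.3-fold lower number from compound 3 to compound 4 (0.36 log units; beyond the scatter) and so separates two aryl-bearing groups. Replacing the nonyl part of the decyl chain with (3-fluorophenyl)carbamoyl gives a 1.6-fold higher number from compound 2 to compound 4 (0.21 log units; within the scatter) and shows that the decyl chain is not alone among these groups in reaching a low number. The data shown give no explanation for either step. Still open, from the compounds shown here alone, is whether the fluorine or the carbamoyl link accompanies the lower number, and how a plain benzyl group or a carboxylic acid would read at this nitrogen.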